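Swapping the Amide Substituent: From Compound 3 to Compound 4

This account rests on a few compounds, and the source may have more. Where it says the series, first, only, none or still open, it means among the compounds named here.

Of the compounds shown here, three with a shared core have been tested in a functional assay on the whole organism with Mus musculus as the target, at a dose of 100 mg/kg by the intraperitoneal route; a higher number here means more inhibition at the dose given (going by the name of the read-out), a lower number less inhibition. Compound 1 `Cc1cccc2c1CC/C2=C\C(=O)NC1CC1` gives 100%, and compound 2 `NC(=O)/C=C1\CCc2cc(F)cc(F)c21` gives 100%. Compound 3 `O=C(/C=C1\CCc2ccc(F)cc21)Nc1ccccc1` gives 83%, the lowest of the three, and its gap to each of the other two lies beyond the usual scatter of repeated measurements. Compound 4 `O=C(/C=C1\CCc2ccc(F)cc21)NC1CCC1` has not yet been measured. It differs from compound 3 in one place: cyclobutyl in place of phenyl on an amide-type nitrogen. For the measured compounds named here, no step between two measured compounds is available to guide this change. An increase is nevertheless expected for compound 4 in this assay, because compound 1 gives 100%. The estimate means a step of a number 12 percentage points higher from compound 3 to compound 4 (beyond the scatter) in inhibition. Compound 4 is estimated at 95%, in a range from 75% to 100%.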

Compound 4, a percentage reported as inhibition, in the whole organism at one dose (the size of the read-out at that dose, not a potency): 100%
Beside the measured number, compound 4's estimate is 5 percentage points below it; the range from low to high includes it.
By their numbers in this assay, from the lowest: compound 3; then compounds 1, 2 and 4 (each within the scatter of the next).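

In this assay the amide-type nitrogen now has its first direct comparison: a modest step, a number 17 percentage points higher from compound 3 to compound 4 (beyond the scatter) when cyclobutyl takes the place of phenyl and the rest of the molecule stays the same. The group on this nitrogen therefore matters to the read-out, and an aromatic ring is not required there for inhibition at this dose. Nothing available explains why the number rises. Still open, on these data alone, is how a non-ring group on this nitrogen, such as an n-butyl chain, would read. A benzyl group, which holds its phenyl ring one carbon further out, is equally untested here.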